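This account rests on a few compounds, and the source may have more. Where it says the series, first, only, none or still open, it means among the compounds named here.

Of the compounds shown here, two that share one core have been measured in a functional assay on Jurkat cells (Homo sapiens) for activation, with a stated time of 24 h; on this read-out lower numbers stand for an effect already at smaller amounts and higher numbers for an effect only at larger amounts of compound. Compound 1 `Cc1cccc(-c2ccc(NCc3ccccc3O)cc2)c1` gives 9190 nM in this assay. Compound 2 `Oc1cccc(-c2ccc(NCc3ccccc3O)cc2)c1` is recorded in this assay as "not active" (no number reported), so no single number stands for it, and where compound 2 sits on the scale cannot be stated beyond the plain fact that compound 1 returned a number and compound 2 did not. The step from compound 2 to compound 3 `CCOc1cccc(-c2ccc(NCc3ccccc3O)cc2)c1` is ethyl in place of hydrogen on an oxygen on an aromatic ring, the same difference read one bond further out being hydroxy to ethoxy. For the measured compounds named here, no measured pair shows this change, so its size and direction in this assay are not known from the present data. Going by the values given here, the only anchor is that compound 1 gives 9190 nM, while compound 2 has no number at all. On these data alone, the change from hydroxy to ethoxy could bring the read-out back to a measurable number or could again leave none; both outcomes remain open. For compound 3 the estimated value in this assay is 12000 nM, expected to fall between 3000 nM and 50000 nM, with a real chance that only an inactive call is reported once more.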

Compound 3, half-maximal effective concentration: "not active" (no number reported)
Compound 3 has no reported number here; there is nothing to compare the estimate with.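

In this assay compound 2 and compound 3 are both recorded as not active, with no number for either, so no step can be read between them. Nothing available here bears on this result. The compounds shown leave open what separates compound 1, the only one with a number, from the other two.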